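The source may hold more compounds than are shown below. What is called first, only, known or untested is meant among the compounds shown, and "the series" means these compounds.

Measured so far in an assay on HEK-293T cells for inhibition of Bile acid receptor (Homo sapiens), read by a beta-lactamase reporter, with a stated time of 16 h; on this read-out higher numbers stand for weaker inhibition and lower numbers for stronger inhibition:
- compound 1, `Cc1ccc(-c2nn(-c3ccc(F)cc3)cc2C(=O)Nc2ccc(C)c(S(=O)(=O)N3CCOCC3)c2)cc1`: 2490 nM
- compound 2, `COc1cccc(Cn2cc(C(=O)Nc3ccc(C)c(S(=O)(=O)N4CCOCC4)c3)c(-c3cccc(OC)c3)n2)c1`: 1240 nM
- compound 3, `Cc1ccc(-c2nn(C(C)C)cc2C(=O)N(C)c2ccc(C)c(S(=O)(=O)N3CCOCC3)c2)cc1`: 16200 nM

Compound 1 stands second highest of the three numbers. Its number and that of compound 2 lie within the scatter of each other, so no order between those two is claimed. Compound 3 gives the clearly higher number, a gap beyond the scatter; compound 3 also differs from compound 1 in more than one place, so nothing is attributed to any single change there.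

The step under consideration goes from compound 1 to compound 4, `Cc1ccc(-c2nn(-c3ccccc3)cc2C(=O)Nc2ccc(C)c(S(=O)(=O)N3CCOCC3)c2)cc1`. The change is hydrogen in place of fluoro on an aromatic carbon, para to a large group; read one bond further out, 4-fluorophenyl becomes phenyl. Going by the values given here, no measured pair in this set isolates this change, so no measured step can be cited for it. A single fluoro lost at this place is expected to move the number little in this assay, with no direction favoured and nothing expected beyond the scatter. The step from compound 1 to compound 4 is therefore estimated at a 1.1-fold higher number from compound 1 to compound 4 (0.05 log units; within the scatter). Compound 4 is expected to give 2800 nM, with a range from 1000 nM to 8000 nM.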

Compound 4, half-maximal inhibitory concentration: 2620 nM
Compound 4: middle estimate off by 1.1-fold (0.03 log units), on the high side; measured number inside the range.
By their numbers in this assay, from the lowest: compounds 2, 1 and 4 (each within the scatter of the next, the first and the last beyond it); then compound 3.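

In this assay, going by these compounds alone, the pair gives a 1.1-fold higher number from compound 1 to compound 4 (0.02 log units; within the scatter) for hydrogen in place of fluoro on an aromatic carbon, para to a large group, the first direct reading of this change. On this pair, 4-fluorophenyl and phenyl cannot be told apart, so the fluoro is not needed at this place for the number to stay within the scatter of compound 1. Nothing available explains this result or bears on it.

The compounds shown compare only fluoro and hydrogen on this carbon, so the effect of a nitrile, an amine or a carboxylic acid there remains open. Also open, on these data alone, is whether the same exchange would read alike on the core of compound 3.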